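The compounds below may be only part of what the source reports. "The series", "measured", "known", "first", "only" and "open" are said of these compounds alone.

Compound 1 `CC(C)CC1n2cncc2CN(Cc2ccc(OC(F)(F)F)cc2)S1(=O)=O`: 13%
Compound 2 `CC(C)CC1n2cncc2CN([C@@H](C)c2ccc(Cl)cc2)S1(=O)=O`: 56%
Compound 3 `C[C@@H](c1ccc(Cl)cc1)N1Cc2cncn2C(C[C@H](O)c2ccccc2)S1(=O)=O`: 6%

In an assay on isolated protein for inhibition of Aromatase (Homo sapiens), tested at 1 uM (a higher number here means more inhibition at the concentration tested (going by the name of the read-out), a lower number less inhibition), compound 1 stands second of the three numbers: compound 3 lies within the scatter of it, while compound 2 lies well above. Among the compounds with values here, the only step measured between two compounds, a number 50 percentage points lower from compound 2 to compound 3 (beyond the scatter), exchanges a group on a saturated chain carbon and says nothing about the aromatic ring. Compound 4 `CC(C)CC1n2cncc2CN(Cc2ccccc2)S1(=O)=O` differs from compound 1 by hydrogen in place of trifluoromethoxy on an aromatic carbon. Within the data shown here, no measured step touches this group; compounds 2 and 3 carry chloro on that ring but differ from compound 1 in more than one place, so their values cannot isolate the change. With nothing pointing either way, compound 4 is expected to show a number 2 percentage points higher from compound 1 to compound 4 (within the scatter), a shift within the scatter. Compound 4 is therefore estimated at 15%, between 3% and 35%.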

Compound 4, a percentage reported as inhibition, at one concentration (the size of the read-out at that concentration, not a potency): 14%
For compound 4 the middle estimate is 1 percentage points above the measured one, within the range that was stated.
By their numbers in this assay, from the lowest: compounds 3, 1 and 4 (each within the scatter of the next); then compound 2.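

In this assay, within the data shown here, hydrogen in place of trifluoromethoxy on an aromatic carbon gives a number 1 percentage points higher from compound 1 to compound 4 (within the scatter), the first step that isolates this position. The two numbers cannot be told apart, so this exchange, which removes all 5 heavy atoms of the group, has no readable effect here. No separate measurement bears on this result.

On these data alone, whether an amine or a carboxylic acid on this carbon would give a different number remains open. So does whether the same exchange would read alike in compound 2.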